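A few compounds are considered here, and "the series" means these few. Any claim that something is new, unique, unknown or untested is made for them only; others in the source may bear on it.

Measured so far:
Compound 1 `COc1ccccc1-n1nc(C2CC(C)(C)OC(C)(C)C2)cc1-c1ccc(C#N)cc1` gives 1 nM in an assay on HEK293 cells for inhibition of Voltage-dependent N-type calcium channel subunit alpha-1B (Homo sapiens), read by fluorescence and calcium flux, with a stated time of 5 min; on this read-out lower numbers stand for stronger inhibition and higher numbers for weaker inhibition.
Compound 2 `COc1ccccc1-n1nc(C2C[C@H](C)O[C@@H](C)C2)cc1-c1ccc(Cl)cc1` gives 2 nM in this assay.
Compound 3 `CC1(C)CC(c2cc(-c3ccc(Cl)cc3)n(-c3ccncc3)n2)CC(C)(C)O1` gives 7 nM in this assay.

Of these three numbers, compound 1 has the lowest. Its gap to compound 2 lies within the usual scatter of repeated measurements, so the two cannot be told apart on this evidence. Its gap to compound 3 lies beyond the scatter, so compound 1 does inhibit more strongly than compound 3.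

Compound 4 `COc1ccccc1-n1nc(C2CC(C)(C)OC(C)(C)C2)cc1-c1csc(Cl)c1` has not yet been measured. It differs from compound 1 in one place: 5-chlorothiophen-3-yl in place of 4-cyanophenyl on an aromatic carbon. For the measured compounds named here, no measured pair shows exactly this exchange, so its size cannot be read off from a step already seen. What the measured set does show is that a chlorine-bearing aromatic ring at the same position of the core is compatible with a low number, since compound 2 carries a 4-chlorophenyl group there and gives 2 nM. On that basis the step is expected to be small, at most a mild weakening, and probably within the scatter. For compound 4 the estimated value is 3 nM, with a likely range from 1 nM to 10 nM. This estimate means a step of a 3.0-fold higher number from compound 1 to compound 4 (0.48 log units; beyond the scatter).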

Compound 4, half-maximal inhibitory concentration: 6 nM
For compound 4 the middle estimate is 2.0-fold (0.30 log units) below the measured one; the measured number falls inside the stated range.
By their numbers in this assay, from the lowest: compounds 1 and 2 (each within the scatter of the next); then compounds 4 and 3 (each within the scatter of the next).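

In this assay, for the compounds shown here, this exchange gives the first measured step at this position of the shared core, a 6.0-fold higher number from compound 1 to compound 4 (0.78 log units; beyond the scatter), and it shows that the group held here does affect inhibition, though the weakening is modest. The position still accepts a very different aromatic group: a five-membered ring carrying sulfur and chlorine replaces a six-membered ring of carbon bearing a nitrile, and compound 4 stays at 6 nM. No measurement available here accounts for the size of this step.

Ring size, the sulfur atom, the loss of the nitrile and the gain of chlorine all change together in this single pair, so their separate contributions cannot be told apart; 4-chlorophenyl on the core of compound 1, with its 2-methoxyphenyl and 2,2,6,6-tetramethyloxan-4-yl groups kept, would test the ring and its substituent separately. The compounds shown also leave open how this position would respond to a group of a different kind, such as an amine or a carboxylic acid on the aromatic ring.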